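Ester to aminoalcohol on the aryl ether chain

This account rests on a few compounds, and the source may have more. Where it says the series, first, only, none or still open, it means among the compounds named here.

Measured compounds:
compound 1, `COc1ccc(-c2cc(-c3ccccc3)no2)c(OCCCN2CCCC2)c1`: 13.4%
compound 2, `CCOC(=O)COc1cc(OC)ccc1-c1cc(-c2ccccc2)no1`: "not determined" (no result reported)

In a functional assay on the whole organism (blood, strain Sprague-Dawley albino) with Rattus norvegicus as the target, with stated times of 30 min and 5 h, at a dose of 100 mg/kg by the oral route (on this read-out higher numbers stand for more inhibition at the one dose given (going by the name of the read-out) and lower numbers for less inhibition), compound 1 gives 13.4%. In this assay compound 2 gives "not determined" (no result reported), so it stands nowhere on the scale shown. Compound 3, `CCN(CC)CC(O)COc1cc(OC)ccc1-c1cc(-c2ccccc2)no1`, differs from compound 2 by 2-(diethylamino)-1-hydroxyethyl in place of ethoxycarbonyl on a saturated chain carbon bound to an oxygen on an aromatic ring. For the measured compounds named here, with no measured step available for this change, the expected size of the step in this assay cannot be read from the data; no shift beyond the usual scatter is assumed. The estimate for compound 3 in this assay is 15%, with a range from 0% to 40%.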

Compound 3, a percentage reported as inhibition, in the whole organism at one dose (the size of the read-out at that dose, not a potency): 11.6%
The estimate for compound 3 lay 3.4 percentage points above the measured number; low and high end bracket the measured number.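

In this assay, 2-(diethylamino)-1-hydroxyethyl in place of 2-(pyrrolidin-1-yl)ethyl on a saturated chain carbon bound to an oxygen on an aromatic ring gives a number 1.8 percentage points lower from compound 1 to compound 3 (within the scatter), so the two amine chains cannot be told apart at this dose. As far as these compounds go, the step from compound 2 cannot be read, as compound 2 has no number, and the size of the ester-to-aminoalcohol change remains unknown. No evidence is available that explains this result. Still open, from the compounds shown here alone, is how a carboxylic acid or a longer chain at this place would read against compound 3.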